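Arylpiperazine variation in a xanthine series at the serotonin-7 receptor

This account rests on a few compounds, and the source may have more. Where it says the series, first, only, none or still open, it means among the compounds named here.

Measured so far:
compound 1 `CCCOc1nc2c(c(=O)n(C)c(=O)n2C)n1CCCN1CCN(c2ccccc2)CC1`: 980 nM
compound 2 `CCCOc1nc2c(c(=O)n(C)c(=O)n2C)n1CCCN1CCN(c2ccccc2OC)CC1`: 328 nM

Among the measured compounds shown here, in an assay on cell membranes (strain Wistar) for displacement of a labelled ligand from 5-hydroxytryptamine receptor 7 (Rattus norvegicus) (on this read-out lower numbers stand for stronger inhibition and higher numbers for weaker inhibition), compound 2 stands lowest of the two numbers, with compound 1 its only neighbour at a 3.0-fold lower number from compound 1 to compound 2 (0.48 log units; beyond the scatter). Compound 3 `CCCOc1nc2c(c(=O)n(C)c(=O)n2C)n1CCCN1CCN(c2cccc(Cl)c2)CC1` differs from compound 2 in one place: 3-chlorophenyl in place of 2-methoxyphenyl on an amine nitrogen in a ring. For the measured compounds named here, the one measured step that bears on it is a 3.0-fold lower number from compound 1 to compound 2 (0.48 log units; beyond the scatter). Going by the values given here, in that step a methoxy takes the place of a hydrogen on an aromatic carbon; compound 3 loses that methoxy, and no measured step covers a 3-chlorophenyl group. Compound 3 is therefore expected to move back toward compound 1, by about a 2.1-fold higher number from compound 2 to compound 3 (0.33 log units; beyond the scatter), and its estimated value in this assay is 700 nM, within 250 nM to 2000 nM.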

Compound 3, inhibition constant: 267 nM
Beside the measured number, compound 3's estimate is 2.6-fold (0.42 log units) above it; the range from low to high includes it.
By their numbers in this assay, from the lowest: compounds 3 and 2 (each within the scatter of the next); then compound 1.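

In this assay, 3-chlorophenyl in place of 2-methoxyphenyl on the ring amine nitrogen gives a 1.2-fold lower number from compound 2 to compound 3 (0.09 log units; within the scatter), so these two groups cannot be told apart here. Chloro in place of hydrogen on an aromatic carbon gives a 3.7-fold lower number from compound 1 to compound 3 (0.56 log units; beyond the scatter), which shows that the methoxy group is not the only substituent on this phenyl ring that separates a compound from compound 1. Nothing available explains this result.

Still open, on these data alone, is whether each group depends on its ring position, as 2-chlorophenyl and 3-methoxyphenyl would show. Also open, as far as these compounds go, is how a hydroxyl or a trifluoromethyl group would compare on this ring.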